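Para-Substituent Swap on the Phenyl Ring: Bromo to Nitro

A few compounds are considered here, and "the series" means these few. Any claim that something is new, unique, unknown or untested is made for them only; others in the source may bear on it.

The measured compounds and their values in an ADME assay on HepG2 cells (Homo sapiens) for cytotoxicity, read by MTT assay, with a stated time of 48 h; on this read-out higher numbers stand for lower toxicity in this test and lower numbers for higher toxicity in this test:

Compound 1, `CC(=O)OC[C@H]1O[C@H](OC[C@@H](Cn2cc(CN(c3nc(-c4ccccc4)no3)C3CCCCC3)nn2)OC(C)=O)C=C[C@@H]1OC(C)=O`: 19.9 ug/mL
Compound 2, `CC(=O)OC[C@H]1O[C@H](OC[C@@H](Cn2cc(CN(c3nc(-c4ccc(F)cc4)no3)C3CCCCC3)nn2)OC(C)=O)C=C[C@@H]1OC(C)=O`: 28.8 ug/mL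
Compound 3, `CC(=O)OC[C@H]1O[C@H](OC[C@@H](Cn2cc(CN(c3nc(-c4ccc(Br)cc4)no3)C3CCCCC3)nn2)OC(C)=O)C=C[C@@H]1OC(C)=O`: 47.6 ug/mL

Compound 3 holds the highest number of the three. Its gap to compound 2 lies within the scatter, and only its gap to compound 1, a 2.4-fold higher number from compound 1 to compound 3 (0.38 log units; beyond the scatter), counts as a real step, and a modest one. The change from compound 1 to compound 2, a 1.4-fold higher number from compound 1 to compound 2 (0.16 log units; within the scatter), stays within the scatter, as does the change from compound 2 to compound 3, a 1.7-fold higher number from compound 2 to compound 3 (0.22 log units; within the scatter).

Compound 4, `CC(=O)OC[C@H]1O[C@H](OC[C@@H](Cn2cc(CN(c3nc(-c4ccc([N+](=O)[O-])cc4)no3)C3CCCCC3)nn2)OC(C)=O)C=C[C@@H]1OC(C)=O`, is to be measured in this assay. It differs from compound 3 as follows: nitro in place of bromo on an aromatic carbon. For the measured compounds named here, no measured step involves a nitro group, so the bearing of the earlier steps is indirect: they show that exchanging one para-substituent for another on this phenyl ring has moved the number by no more than a modest amount, and mostly within the scatter. Compound 4 is therefore expected to sit close to compound 3, with the step of a 1.3-fold lower number from compound 3 to compound 4 (0.10 log units; within the scatter) expected to fall within the scatter. The estimate for compound 4 is 38 ug/mL, with a range from 17 ug/mL to 85 ug/mL.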

Compound 4, half-maximal cytotoxic concentration: > 200 ug/mL
Compound 4: a limit, no number; the forecaster's own chance of this, stated with the estimate: 5%; middle value at least 5.2-fold (0.72 log units) from the limit.
By their numbers in this assay, from the lowest: compounds 1, 2 and 3 (each within the scatter of the next, the first and the last beyond it). At a limit, above all of these: compound 4.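

In this assay compound 4 gives > 200 ug/mL, which is a limit of the assay and not a number: the limit of > 200 ug/mL in this assay, at which 1 of the 4 values shown sits.

Going from 4-bromophenyl to 4-nitrophenyl gives an at least 4.2-fold higher number from compound 3 to compound 4 (0.62 log units; beyond the scatter), and the comparisons with the two other compounds read an at least 6.9-fold higher number from compound 2 to compound 4 (0.84 log units; beyond the scatter) and an at least 10-fold higher number from compound 1 to compound 4 (1.00 log units; beyond the scatter). Among hydrogen, fluoro and bromo, the only step beyond the scatter was the modest one of a 2.4-fold higher number from compound 1 to compound 3 (0.38 log units; beyond the scatter), so this aromatic carbon had not yet shown that one exchange of a single group could move the read-out so much further, toward lower toxicity in this test.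

The compounds shown leave open whether this shift belongs to the nitro group alone or would also appear with an amine, a carboxylic acid or a nitrile on the same aromatic carbon. They also leave open whether the nitro group would have the same effect if the shared core carried a longer chain in place of its cyclohexyl group.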